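A few compounds are considered here, and "the series" means these few. Any claim that something is new, unique, unknown or untested is made for them only; others in the source may bear on it.

Measured so far:
- compound 1 `COC(=O)C(Nc1cc(CS(=O)(=O)/C=C/c2c(OC)cc(OC)cc2OC)ccc1OC)c1ccc(OC)cc1` gives 250 nM in the working series
- compound 2 `COc1cc(OC)c(/C=C/S(=O)(=O)Cc2ccc(OC)c(NC(C(=O)O)c3ccccc3)c2)c(OC)c1` gives 20 nM in the working series

For the measured compounds named here, both numbers come from a functional assay on DU-145 cells (Homo sapiens) for cytotoxicity, read by trypan blue exclusion, with a stated time of 96 h (a higher number here means a weaker inhibitor, a lower number a stronger inhibitor), and are the only readings available. Compound 2 holds the lower of the two numbers, and the gap up to compound 1 lies beyond the scatter.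

Going by the values given here, compound 3 `COc1ccc(C(Nc2cc(CS(=O)(=O)/C=C/c3c(OC)cc(OC)cc3OC)ccc2OC)C(=O)O)cc1` has no measurement yet. Its structure differs from that of compound 2 by one change: methoxy in place of hydrogen on an aromatic carbon with methoxy in place of hydrogen on an aromatic carbon, so that phenyl becomes 4-methoxyphenyl.

Among the compounds with values here, no measured pair isolates this change, so the expectation has no direct precedent. In this assay a small step toward a higher number is expected, possibly none beyond the scatter. The estimated change is a 1.5-fold higher number from compound 2 to compound 3 (0.18 log units; within the scatter) for this single substitution. The expected value for compound 3 is 30 nM with an estimated range from 10 nM to 100 nM in this assay.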

Compound 3, half-maximal inhibitory concentration: 100 nM
Estimate against measurement, compound 3: 3.3-fold (0.52 log units) below; the range from low to high includes it.
By their numbers in this assay, from the lowest: compound 2; then compound 3; then compound 1.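

In this assay, this aromatic carbon, para to a large group, proves sensitive to substitution: methoxy in place of hydrogen, turning phenyl into 4-methoxyphenyl, gives a clear loss (a 5.0-fold higher number from compound 2 to compound 3 (0.70 log units; beyond the scatter)). With 4-methoxyphenyl held constant, the free acid also separates from its methyl ester, as hydrogen in place of methyl on the oxygen next to the carbonyl group gives a modest gain (a 2.5-fold lower number from compound 1 to compound 3 (0.40 log units; beyond the scatter)). No measurement at hand accounts for either step.

On these data alone, whether the loss belongs to methoxy specifically or to any group at this place remains open, and a fluorine, a hydroxyl or a methyl there would help to separate the two. Also open, as far as these compounds go, is how an amide or a nitrile would compare with the carboxylic acid on the same core.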